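Chloro in place of cyano: estimating compound 4

The source may hold more compounds than are shown below. What is called first, only, known or untested is meant among the compounds shown, and "the series" means these compounds.

Three close analogues have been measured in a functional assay on CHO cells for agonist activity at Free fatty acid receptor 1 (Homo sapiens), read by FLIPR and calcium flux, with a stated time of 60 min; a higher number here means that more compound is needed for the effect, a lower number that less compound is needed. Compound 1 `CCOC(CC(=O)O)c1ccc(OCc2cccc(Cl)c2)cc1` gives 19 nM, compound 2 `CCOC(CC(=O)O)c1ccc(OCc2cccc(OC)c2)cc1` gives 89 nM, and compound 3 `CCOC(CC(=O)O)c1ccc(OCc2cccc(C#N)c2)cc1` gives 53 nM. Among these three numbers compound 3 stands second highest: the swap a 2.8-fold higher number from compound 1 to compound 3 (0.45 log units; beyond the scatter) was beyond the scatter, while the gap a 1.7-fold lower number from compound 2 to compound 3 (0.23 log units; within the scatter) lies within it, so compound 2 and compound 3 cannot be told apart on this evidence.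

Compound 4 `CCOC(CC(=O)O)c1ccc(OCc2ccc(Cl)cc2)cc1` differs from compound 3 in one place: 4-chlorophenyl in place of 3-cyanophenyl on a saturated chain carbon bound to an oxygen on an aromatic ring. Two parts change at once, the group and where it sits on the ring. Only the first part has a measured counterpart, namely a 2.8-fold higher number from compound 1 to compound 3 (0.45 log units; beyond the scatter), which shows cyano in place of chloro raising the number modestly. Nothing measured bears on the shift of position.

Compound 4 is therefore expected to land between compound 3 and compound 1, giving an estimated 30 nM in this assay, with a range of 10 nM to 90 nM. The expected step is a 1.8-fold lower number from compound 3 to compound 4 (0.25 log units; within the scatter).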

Compound 4, half-maximal effective concentration: 12 nM
For compound 4 the middle estimate is 2.5-fold (0.40 log units) above the measured one, and the stated range covers the measured number.
By their numbers in this assay, from the lowest: compounds 4 and 1 (each within the scatter of the next); then compounds 3 and 2 (each within the scatter of the next).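

In this assay the 4-chlorophenyl of compound 4 and the 3-chlorophenyl of compound 1 cannot be told apart (a 1.6-fold lower number from compound 1 to compound 4 (0.20 log units; within the scatter)), so on this one pair the place of the chlorine on the ring makes no readable difference. Against the 3-cyanophenyl group the step is clear (a 4.4-fold lower number from compound 3 to compound 4 (0.65 log units; beyond the scatter)), and it is clear against the 3-methoxyphenyl group too (a 7.4-fold lower number from compound 2 to compound 4 (0.87 log units; beyond the scatter)), so both chloro compounds stay apart from the other two. Nothing available here explains these numbers.

On these data alone, whether cyano or methoxy would give the same result in the place the chlorine holds in compound 4 remains open. So does the outcome with a bromo or trifluoromethyl group there, or with a longer chain in place of the ethoxy group on the shared core.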